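From 2-hydroxyphenyl to 2-methoxyphenyl: an expected step

The compounds below may be only part of what the source reports. "The series", "measured", "known", "first", "only" and "open" are said of these compounds alone.

Compound 1 `CCC/N=C1\S/C(=C\c2ccc(O)c(Cl)c2)C(=O)N1C1CCS(=O)(=O)CC1` gives 2.6
Compound 2 `CCC/N=C1\S/C(=C\c2ccc(O)c(Cl)c2)C(=O)N1C(C)C` gives > 4.3
Compound 3 `CCC/N=C1\S/C(=C\c2ccc(O)c(Cl)c2)C(=O)N1c1ccccc1O` gives 2.7

In a physicochemical assay for lipophilicity, read by HPLC, at pH 7.4 (a higher number here means a more lipophilic compound, a lower number a more polar compound), compound 3 gives 2.7 and lies within the scatter of compound 1 with 2.6 on the same scale. Compound 2 reads > 4.3 here, which is a limit of the assay and not a number.

Compound 4 `CCC/N=C1\S/C(=C\c2ccc(O)c(Cl)c2)C(=O)N1c1ccccc1OC` differs from compound 3 in one place, with methyl in place of hydrogen on an oxygen on an aromatic ring, so that 2-hydroxyphenyl becomes 2-methoxyphenyl (methyl in place of hydrogen on an oxygen on an aromatic ring).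

For the measured compounds named here, no measured step makes this change. The steps at hand all swap the group on an amide-type nitrogen in a ring, and their sizes differ widely: a number at least 1.70 log units higher from compound 1 to compound 2 (beyond the scatter) and a number at least 1.60 log units lower from compound 2 to compound 3 (beyond the scatter) are large, while a number 0.10 log units higher from compound 1 to compound 3 (within the scatter) is not. Those steps exchange whole groups, whereas this one adds a single methyl, so nothing of their large size is expected here. A modest rise in this assay is the expectation, at about the edge of the scatter or a little past it, and it rests on thin evidence.

The expected change is a number 0.50 log units higher from compound 3 to compound 4 (beyond the scatter) in this estimate. For compound 4 the estimated value is 3.2 with an expected range from 2.7 to 3.9 in this assay.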

Compound 4, distribution coefficient: 3.3
For compound 4 the middle estimate is 0.10 log units below the measured one; low and high end bracket the measured number.
By their numbers in this assay, from the lowest: compounds 1 and 3 (each within the scatter of the next); then compound 4. At a limit, above all of these: compound 2.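

In this assay, for the compounds shown here, the change on this oxygen counts for more than the earlier compounds could show: the step reads a number 0.60 log units higher from compound 3 to compound 4 (beyond the scatter) with only methyl in place of hydrogen on an oxygen on an aromatic ring. The earlier compounds shown here had left 2-hydroxyphenyl within the scatter of 1,1-dioxothian-4-yl, whereas 2-methoxyphenyl separates from that group with a number 0.70 log units higher from compound 1 to compound 4 (beyond the scatter) on the same amide-type nitrogen in a ring. Isopropyl still stands apart with a number at least 1.00 log units lower from compound 2 to compound 4 (beyond the scatter) and that size has only one bound, the reading for compound 2 being a limit and not a number: the limit of > 4.3 in this assay, at which 1 of the 4 values shown sits.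

The compounds shown leave open whether the rise stops at methyl or goes on with a longer chain such as ethyl or propyl on this oxygen, and how an amine or a fluorine in place of the hydroxy would read. From the compounds shown here alone, this step also stands alone, so whether methyl on this oxygen gives a step of the same size on any other core remains unknown.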